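The compounds below may be only part of what the source reports. "The series", "measured", "known", "first", "only" and "open" are said of these compounds alone.

Of the compounds shown here, two sharing one core have so far been measured in a functional assay (Homo sapiens) for inhibition of Nucleic Acid, tested at 100 uM; a lower number here means less inhibition, a higher number more inhibition at the concentration tested (going by the name of the read-out). Compound 1 `OC[C@H]1O[C@@H](n2cnc3c(NCc4ccccc4)nccc32)C[C@@H]1O` gives 15% in that test. Compound 2 `OC[C@H]1OC(n2cnc3c(NCc4ccccc4)nccc32)[C@H](O)[C@@H]1O` gives 32% in the same test, which is the higher of the two numbers, and the gap between compound 2 and compound 1 lies beyond the usual scatter of repeated runs. Compound 3 `[N-]=[N+]=Nc1nccc2c1ncn2C1O[C@H](CO)[C@@H](O)[C@H]1O` has not yet been measured in this assay. It differs from compound 2 in one place: azido in place of benzylamino on an aromatic carbon. Within the data shown here, no step between measured compounds covers a change of this kind, so nothing measured here tells its direction or size. The benzylamino group that leaves brings one six-membered aromatic ring of carbon only and one hydrogen-bond donor, neither of which the entering azido group has. Because compound 2 sits at 32%, a fall of moderate size is expected, and the estimated step of a number 17 percentage points lower from compound 2 to compound 3 (beyond the scatter) is taken to point downward. Compound 3 is expected to give about 15% in this assay, within a range from 0% to 40%.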

Compound 3, a percentage reported as inhibition, at one concentration (the size of the read-out at that concentration, not a potency): 4%
Estimate against measurement, compound 3: 11 percentage points above; the range from low to high includes it.
By their numbers in this assay, from the lowest: compound 3; then compound 1; then compound 2.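

The exchange of benzylamino for azido is the only change shown at this aromatic carbon, next to the ring nitrogen, and in this assay it gives a number 28 percentage points lower from compound 2 to compound 3 (beyond the scatter). The position is therefore not indifferent to what it carries, at least on the background of compound 2, and the change leaves the rest of that structure as it was. Several things change at once in this single step, since the benzylamino group takes away its six-membered aromatic ring of carbon only and its hydrogen-bond donor while the azido group brings a smaller, ring-free substituent made of nitrogen alone, and no measurement given here explains the fall in inhibition.

The compounds shown leave open whether the fall follows the loss of the aromatic ring, the loss of the hydrogen-bond donor or the arrival of the azido group itself. From the compounds shown here alone, an amine on the same carbon, or a phenethylamino group with its longer chain, would be needed to pull these apart, and what either would do in this test remains unknown.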